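Hydroxamate-bearing anilinoquinazolines: dichlorophenyl pattern on a short linker

The source may report more compounds than this note shows. Statements on the series, on what has been measured and on what is new or still open speak of the compounds shown alone.

Of the compounds shown here, two have been measured so far. Compound 1 `COc1cc2ncnc(Nc3cc(Cl)ccc3Cl)c2cc1OCCCCCC(=O)NO` in a functional assay on MCF7 cells (Homo sapiens) for antiproliferative activity, read by MTT assay, with a stated time of 48 h (on this read-out lower numbers stand for stronger inhibition and higher numbers for weaker inhibition), gives 4000 nM. Compound 2 `COc1cc2ncnc(Nc3ccc(Cl)cc3Cl)c2cc1OCCCC(=O)NO` in this assay gives 56800 nM, the highest of the two numbers and beyond the scatter away from compound 1. Among the measured compounds shown here, compound 1 and compound 2 differ in more than one place, so their values set no single-change step.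

Compound 3 `COc1cc2ncnc(Nc3cc(Cl)ccc3Cl)c2cc1OCCCC(=O)NO` is not yet measured. It differs from compound 2 in one place: 2,5-dichlorophenyl in place of 2,4-dichlorophenyl on a nitrogen on an aromatic ring. For the measured compounds named here, compound 3 carries the same 2,5-dichlorophenyl as compound 1, so the pair compound 2 to compound 3 gives the first clean reading of this aryl pattern on the shared core. Going by the values given here, no measured step of this kind exists, and nothing in the two values shows how much of the gap between compound 1 and compound 2 belongs to the aryl pattern. The expectation is a moderate move toward a lower number, with wide uncertainty. Compound 3 is expected near 20000 nM, between 6000 nM and 60000 nM. The expected step of a 2.8-fold lower number from compound 2 to compound 3 (0.45 log units; beyond the scatter) is toward a lower number, but could also fall within the scatter.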

Compound 3, half-maximal inhibitory concentration: 44500 nM
Estimate against measurement, compound 3: 2.2-fold (0.35 log units) below; the measured number falls inside the stated range.
By their numbers in this assay, from the lowest: compound 1; then compounds 3 and 2 (each within the scatter of the next).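

In this assay, 2,5-dichlorophenyl in place of 2,4-dichlorophenyl on a nitrogen on an aromatic ring gives a 1.3-fold lower number from compound 2 to compound 3 (0.11 log units; within the scatter), so on this short chain the two chlorine patterns cannot be told apart. The chain change gives the first single-change reading at the other end of the series: hydroxycarbamoyl in place of 2-(hydroxycarbamoyl)ethyl on a saturated chain carbon, three bonds along the chain from an oxygen on an aromatic ring, gives an 11-fold higher number from compound 1 to compound 3 (1.05 log units; beyond the scatter) and is the only step shown that lies beyond the scatter. No measurement at hand offers a reason for either step.

The compounds shown leave open whether the two chlorine patterns also read alike on the longer chain of compound 1, where only the 2,5-dichlorophenyl form appears here. They also leave open how a chain longer than that of compound 1, or a carboxylic acid in place of the hydroxycarbamoyl, would read on the shared core.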